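Adding One Carbon to the Methylamino Chain

A few compounds are considered here, and "the series" means these few. Any claim that something is new, unique, unknown or untested is made for them only; others in the source may bear on it.

In a functional assay on A2780 cells (Homo sapiens) for antiproliferative activity, read by MTT assay, with a stated time of 48 h (a higher number here means a weaker inhibitor, a lower number a stronger inhibitor), compound 1 `COc1ccc(C(=O)c2ccc3c(c2)C=CC(C)(C)O3)c(NC(=O)CO)c1` gives 130 nM, compound 2 `COc1ccc(C(=O)c2ccc3c(c2)C=CC(C)(C)O3)c(NC(=O)CN)c1` gives 590 nM and compound 3 `CNCC(=O)Nc1cc(OC)ccc1C(=O)c1ccc2c(c1)C=CC(C)(C)O2` gives 850 nM. Compound 3 sits at the weak end of this set, matched by compound 2 within the scatter, while a 6.5-fold higher number from compound 1 to compound 3 (0.82 log units; beyond the scatter) lies beyond it.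

Compound 4 `CCNCC(=O)Nc1cc(OC)ccc1C(=O)c1ccc2c(c1)C=CC(C)(C)O2` differs from compound 3 by methyl in place of hydrogen on a saturated chain carbon bound to an amine nitrogen, turning methylamino into ethylamino. Among the compounds with values here, the closest precedent is the methyl added on the amine nitrogen, a 1.4-fold higher number from compound 2 to compound 3 (0.16 log units; within the scatter), which stayed within the scatter. The larger 4.5-fold higher number from compound 1 to compound 2 (0.66 log units; beyond the scatter) replaced hydroxy, a different kind of change. In this assay, the expected result is a 1.2-fold higher number from compound 3 to compound 4 (0.07 log units; within the scatter), no shift beyond the scatter. For compound 4 the estimated value is 1000 nM, with an expected range of 450 nM to 2200 nM.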

Compound 4, half-maximal inhibitory concentration: 2070 nM
Compound 4: middle estimate off by 2.1-fold (0.32 log units), on the low side; the measured number falls inside the stated range.
By their numbers in this assay, from the lowest: compound 1; then compounds 2 and 3 (each within the scatter of the next); then compound 4.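

Extending methylamino to ethylamino gives a step beyond the scatter (a 2.4-fold higher number from compound 3 to compound 4 (0.39 log units; beyond the scatter)), whereas the earlier methyl on the amine nitrogen stayed within it, so the size of the group on this nitrogen begins to register only at ethyl. Measured against the unsubstituted amine, ethyl in place of hydrogen gives a clear rise (a 3.5-fold higher number from compound 2 to compound 4 (0.55 log units; beyond the scatter)). Measured against hydroxy, the ethylamino group gives the widest gap in the set (a 16-fold higher number from compound 1 to compound 4 (1.20 log units; beyond the scatter)).

Nothing available explains these shifts. On these data alone, whether a longer chain such as propylamino, or a ring amine such as pyrrolidine, would raise the number further remains open.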